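The source may hold more compounds than are shown below. What is called first, only, known or untested is meant among the compounds shown, and "the series" means these compounds.

Three compounds sharing one core were tested in an assay on isolated protein for inhibition of Rho-associated protein kinase 1 (Homo sapiens), read by scintillation counting, radiometric assay and 33P incorporation, with a stated time of 40 min, in the presence of a further agent that is not named here; a higher number here means a weaker inhibitor, a lower number a stronger inhibitor. Compound 1 `COc1cccc(OCC(=O)Nc2cccc(NC(=O)c3ccc(N(C)C)cc3)c2)c1` reaches only the limit of this assay, giving > 10000 nM; this is the limit of > 10000 nM in this assay, at which 1 of the 3 values shown sits. Compound 2 `CN(C)c1ccc(C(=O)Nc2cccc(NC(=O)COc3ccc4c(c3)OCCC4=O)c2)cc1` gives 144 nM in this assay, which amounts to a step of an at least 69-fold lower number from compound 1 to compound 2 (1.84 log units; beyond the scatter). Compound 3 `CCc1ccc(C(=O)Nc2cccc(NC(=O)COc3ccc4c(=O)ccoc4c3)c2)cc1` gives 235 nM in this assay, the highest of the two numbers, with compound 2 nearest at a gap that stays within the scatter.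

Compound 4 `Cn1ccc(S(=O)(=O)Nc2cccc(NC(=O)COc3ccc4c(=O)ccoc4c3)c2)n1` differs from compound 3 in one place: a group of 9 heavy atoms (4 carbon, 2 nitrogen, 2 oxygen, 1 sulfur; one five-membered aromatic ring with 2 hetero atoms) in place of a group of 10 heavy atoms (9 carbon, 1 oxygen; one six-membered aromatic ring of carbon only), on a nitrogen on an aromatic ring. Among the compounds with values here, no measured step touches this part of the molecule; the single step seen, from compound 1 to compound 2, sits on an oxygen on a saturated carbon and says nothing about an exchange on a nitrogen on an aromatic ring. The expectation for compound 4 therefore rests on little, and the exchange is expected to shift this assay by a 6.4-fold higher number from compound 3 to compound 4 (0.81 log units; beyond the scatter), with wide uncertainty. Compound 4 is estimated at 1500 nM, between 300 nM and 8000 nM.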

Compound 4, half-maximal inhibitory concentration: > 10000 nM
Compound 4 ended at the assay's limit; the forecaster's own chance of this, stated with the estimate: 25%; at least 6.6-fold (0.82 log units) between middle value and limit.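

The step at this place is large: putting the group with the five-membered aromatic ring with 2 hetero atoms in place of (4-ethylphenyl)carbonyl, on a nitrogen on an aromatic ring, gives an at least 42-fold higher number from compound 3 to compound 4 (1.62 log units; beyond the scatter). Within the data shown here, until now, the only step read in this assay lay on an oxygen on a saturated carbon, so this shows that the group on the nitrogen can also decide whether a compound registers in this assay. The result for compound 4 is a limit of the assay and not a number, so its true distance from compound 3 stays unknown: the limit of > 10000 nM in this assay, at which 2 of the 4 values shown sit.

The exchange replaces both the carbonyl and the six-membered aromatic ring at once, so the compounds shown cannot tell which of these changes matters. A phenylsulfonyl group on the same nitrogen would separate the two.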